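Exposure series: shortening the carboxyalkyl chain in compound 2

The source may hold more compounds than are shown below. What is called first, only, known or untested is meant among the compounds shown, and "the series" means these compounds.

Compound 1 `O=C(O)Cn1nc(Cc2nc3cc(Cl)c(OCC(F)F)cc3[nH]2)c2ccccc2c1=O` gives 55 ng.h/mL in an ADME assay on the whole organism (Mus musculus, strain CD1) for pharmacokinetics, read by LC-MS, with a stated time of 24 h, at a dose of 5 mg/kg by the oral route; a higher number here means more compound in the circulation at the dose given, a lower number less compound in the circulation. Compound 2 `CCC(C(=O)O)c1nn(Cc2cn3cc(OCC4CC4)c(Cl)cc3n2)c2ccccc2c1=O` gives 1260 ng.h/mL in this assay, and compound 3 `CC(C(=O)O)c1nn(Cc2cn3cc(OCC4CC4)c(C(F)(F)F)cc3n2)c2ccccc2c1=O` gives 4070 ng.h/mL. On these three numbers compound 2 stands second highest: compound 3 lies nearest, beyond the scatter on the high side, while compound 1 lies furthest away, well below. Compound 4 `C[C@H](C(=O)O)c1nn(Cc2cn3cc(OCC4CC4)c(Cl)cc3n2)c2ccccc2c1=O` is not yet measured in this assay. The change from compound 2 is 1-carboxyethyl in place of 1-carboxypropyl on an aromatic carbon; compound 4 also carries one defined stereocentre. Among the measured compounds shown here, no step between two measured compounds isolates this change. For the measured compounds named here, the two values of compound 2 and compound 3 differ in more than one place, so they show only that a 1-carboxyethyl-bearing member of the series can reach a higher number. For compound 4 the expected step in this assay is a modest rise, a 1.4-fold higher number from compound 2 to compound 4 (0.15 log units; within the scatter), possibly within the scatter. Compound 4 is therefore estimated at 1800 ng.h/mL, with a range from 700 ng.h/mL to 4500 ng.h/mL.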

Compound 4, area under the concentration-time curve: 2790 ng.h/mL
Beside the measured number, compound 4's estimate is 1.6-fold (0.19 log units) below it, within the range that was stated.
By their numbers in this assay, from the lowest: compound 1; then compound 2; then compounds 4 and 3 (each within the scatter of the next).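

Among the compounds shown here, at the aromatic carbon next to the ring nitrogen, 1-carboxyethyl in place of 1-carboxypropyl gives a 2.2-fold higher number from compound 2 to compound 4 (0.35 log units; beyond the scatter) in this assay, the first reading of this change against an otherwise unchanged structure. The shorter chain therefore keeps the compound in the circulation at the dose given, and the number moves upward rather than being lost, though compound 4 also carries one defined stereocentre, so the step cannot be assigned to chain length alone. Nothing in hand explains the step.

Open, from the compounds shown here alone, are the opposite stereoisomer of compound 4 and a 1-carboxybutyl chain at this carbon, which would separate the stereocentre from chain length. Also open, going by these compounds, is whether an amide in place of the carboxylic acid keeps the higher number.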